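From Methyl to Fluoro: What to Expect for Compound 3

The compounds below may be only part of what the source reports. "The series", "measured", "known", "first", "only" and "open" are said of these compounds alone.

Of the compounds shown here, two measured so far share one core and differ only in a single group on a ring at the far end. Compound 1 `O=C(NCCO)c1cccc2c1CCN2c1cc(Cc2cccc(C(F)(F)F)c2)ncn1` carries a trifluoromethyl there, and in a functional assay on HEK293 cells for agonist activity at G-protein coupled receptor 52 (Homo sapiens), read by cAMP accumulation, with a stated time of 15 min (on this read-out higher numbers stand for an effect only at larger amounts of compound and lower numbers for an effect already at smaller amounts), compound 1 gives 101 nM. Compound 2 `Cc1cccc(Cc2cc(N3CCc4c(C(=O)NCCO)cccc43)ncn2)c1` carries a methyl instead, and in this assay compound 2 gives 90 nM. The move between them, a 1.1-fold lower number from compound 1 to compound 2 (0.05 log units; within the scatter), is too small to read as a real change, so the two numbers are best seen as equal. Compound 2 holds the lowest number of the two, with compound 1 within the scatter of it.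

Compound 3 `O=C(NCCO)c1cccc2c1CCN2c1cc(Cc2cccc(F)c2)ncn1` continues along the same place: fluoro in place of methyl on an aromatic carbon. Going by the values given here, the only step that bears on it is the one from compound 1 to compound 2, which shows that exchanging a trifluoromethyl for a methyl at this position left the number unchanged. Nothing measured tells how a fluoro behaves there, so the expectation leans on that single flat step. Compound 3 is therefore expected to show a step of a 1.7-fold higher number from compound 2 to compound 3 (0.22 log units; within the scatter), with a modest loss considered possible but not certain. The estimate for compound 3 in this assay is 150 nM, with a plausible range from 60 nM to 400 nM.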

Compound 3, half-maximal effective concentration: 106 nM
Compound 3: the middle estimate sits 1.4-fold (0.15 log units) above what was measured, and the stated range covers the measured number.
By their numbers in this assay, from the lowest: compounds 2, 1 and 3 (each within the scatter of the next).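

The new compound widens what this position is known to accept. In this assay, fluoro in place of methyl gives a 1.2-fold higher number from compound 2 to compound 3 (0.07 log units; within the scatter) and fluoro in place of trifluoromethyl gives a 1.0-fold higher number from compound 1 to compound 3 (0.02 log units; within the scatter) so neither step can be read as a real change, and the three numbers are best seen as equal. Going by these compounds alone, the earlier pair compared only two groups attached through carbon, whereas compound 3 shows that a single fluorine atom placed directly on this aromatic carbon gives the same read-out within the scatter, so across these three compounds the number does not depend on which of these groups sits here. No other kind of measurement is available to explain why the three numbers agree.

The compounds shown leave open whether this flat picture extends to groups of a different kind at this place, such as an amine, a carboxylic acid or a longer chain like butyl, or to a plain hydrogen. They also leave open whether any of these three groups would give the same number on a different carbon of this ring.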